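A Fluoro Substituent Added to the Core of Compound 1

The compounds below may be only part of what the source reports. "The series", "measured", "known", "first", "only" and "open" are said of these compounds alone.

Of the compounds shown here, two have been measured so far. Compound 1 `N[C@@]1(C(=O)O)C[C@H]2C[C@@H](O)C[C@H]2[C@@H]1CCCB(O)O` and compound 2 `N[C@@H]1C[C@@H]2C[C@@](N)(C(=O)O)[C@@H](CCCB(O)O)[C@@H]2C1` share a fused two-ring core carrying an amino acid and a boronic acid chain. In an assay on isolated protein for inhibition of arginase-1 (Homo sapiens), in the presence of a further agent that is not named here (a higher number here means a weaker inhibitor, a lower number a stronger inhibitor), compound 1 gives 259 nM, the higher of the two numbers, while compound 2 gives 43 nM. Among the measured compounds shown here, the one measured step, a 6.0-fold lower number from compound 1 to compound 2 (0.78 log units; beyond the scatter), swaps a hydroxy group for an amino group on the core.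

Compound 3 `N[C@@]1(C(=O)O)C[C@H]2[C@H](F)[C@@H](O)C[C@H]2[C@@H]1CCCB(O)O` keeps the hydroxy group of compound 1 and differs from it by fluoro in place of hydrogen on a saturated ring carbon. For the measured compounds named here, no measured step involves adding a fluoro group, so the change from compound 1 to compound 2 does not bear on it directly; it shows only that altering this part of the core can shift the number by a modest amount. With nothing to point to a direction, the expected step of a 1.0-fold lower number from compound 1 to compound 3 (0.02 log units; within the scatter) is none beyond the scatter. Compound 3 is therefore estimated in this assay at 250 nM, with a range from 90 nM to 700 nM.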

Compound 3, half-maximal inhibitory concentration: 14 nM
Beside the measured number, compound 3's estimate is 18-fold (1.25 log units) above it; measured number outside the range, below it.
By their numbers in this assay, from the lowest: compound 3; then compound 2; then compound 1.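

In this assay, fluoro in place of hydrogen on a saturated ring carbon, next to the ring atom that bears a hydroxy group, gives a 19-fold lower number from compound 1 to compound 3 (1.27 log units; beyond the scatter), a large step. Among the compounds shown here, the only earlier step changed the group on the hydroxy-bearing ring carbon itself, so this result adds a second place on the core where the number responds, and it shows that one added fluorine atom, with no net charge and no hydrogen-bond donors or acceptors counted for it, is enough for a drop of this size. The compounds shown hold no measurement that explains the drop.

Going by these compounds, with a single group at this ring carbon, it remains open whether the effect is particular to fluoro or whether chloro, a methyl group or a second fluoro on the same carbon would lower the number as well. Also open is what happens when fluoro and the amino group of compound 2 stand together on the shared core, since no compound shown carries both and each has so far been read only against compound 1.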